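A Chloro Group Added to a Furan Ring

The source may report more compounds than this note shows. Statements on the series, on what has been measured and on what is new or still open speak of the compounds shown alone.

In a functional assay on HCT-15 cells (Homo sapiens) for cytotoxicity, read by ELISA, with a stated time of 4 days (on this read-out higher numbers stand for weaker inhibition and lower numbers for stronger inhibition), compound 1 `Cc1ccsc1-c1cc(-c2ccco2)cc(-c2ccc(Cl)cc2)n1` gives 710 nM, compound 2 `Clc1ccc(-c2cc(-c3ccco3)cc(-c3ccc(Cl)s3)n2)cc1` gives 1080 nM and compound 3 `Clc1ccc(-c2cc(-c3ccoc3)cc(-c3cccnc3)n2)s1` gives 720 nM, so compound 2 stands level with the other two, within the usual scatter. Compound 4 `Clc1ccc(-c2cc(-c3ccc(Cl)o3)cc(-c3ccc(Cl)s3)n2)cc1` differs from compound 2 in one place: chloro in place of hydrogen on an aromatic carbon, which turns furan-2-yl into 5-chlorofuran-2-yl. Going by the values given here, no measured pair shows this exact change on a furan. The nearest evidence is a 1.5-fold higher number from compound 1 to compound 2 (0.18 log units; within the scatter), a change on a thiophene ring that stayed within the scatter. On that slim basis, no shift beyond the scatter is expected in this assay, and the expected change is a 1.1-fold lower number from compound 2 to compound 4 (0.06 log units; within the scatter). Compound 4 is estimated at 950 nM, with an expected range of 380 nM to 2400 nM.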

Compound 4, half-maximal inhibitory concentration: 25300 nM
Estimate against measurement, compound 4: 27-fold (1.43 log units) below; measured number outside the range, above it.
By their numbers in this assay, from the lowest: compounds 1, 3 and 2 (each within the scatter of the next); then compound 4.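

Putting chloro in place of hydrogen on the furan ring, next to the ring oxygen, gives a 23-fold higher number from compound 2 to compound 4 (1.37 log units; beyond the scatter) in this assay, which means much weaker inhibition. Going by these compounds alone, the only earlier step, on a thiophene ring, stayed within the scatter, so this furan carbon is the first place where one added atom clearly matters. Nothing shown here explains the loss.

From the compounds shown here alone, whether chloro itself or any group on this carbon causes the drop stays open; a methyl group or an amine there would help tell these apart. Going by these compounds, whether the step holds with different groups elsewhere on the shared core is also open.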